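Chain lengthening on a urea series and a further step

This account rests on a few compounds, and the source may have more. Where it says the series, first, only, none or still open, it means among the compounds named here.

Compound 1 `CCc1ccc(NC(=O)N[C@H](C)c2ccccc2)cc1`: 47%
Compound 2 `CCCc1ccc(NC(=O)N[C@H](C)c2ccccc2)cc1`: 31%
Compound 3 `CCCCCc1ccc(NC(=O)N[C@H](C)c2ccccc2)cc1`: 101%

In an ADME assay on the whole organism with Oryza sativa as the target, tested at 1 uM (on this read-out higher numbers stand for a weaker effect at the one concentration tested and lower numbers for a stronger effect), compound 3 gives the highest of the three numbers, standing a number 54 percentage points higher from compound 1 to compound 3 (beyond the scatter) and a number 70 percentage points higher from compound 2 to compound 3 (beyond the scatter). Compound 4 `CCCCCCc1ccc(NC(=O)N[C@H](C)c2ccccc2)cc1` carries one further change from compound 3: methyl in place of hydrogen on a saturated chain carbon, five bonds along the chain from an aromatic carbon.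

Two earlier steps bear on this. A methyl in place of hydrogen on the chain, two bonds from the aromatic carbon, gave a number 16 percentage points lower from compound 1 to compound 2 (beyond the scatter), a modest drop. Longer extensions, by contrast, gave large rises: a number 54 percentage points higher from compound 1 to compound 3 (beyond the scatter) and a number 70 percentage points higher from compound 2 to compound 3 (beyond the scatter). The numbers therefore do not move in one direction as the chain grows, with compound 2 going against a simple trend. Since compound 3 already sits near the top of the percentage scale, a further methyl is expected to produce little beyond the scatter, with the step estimated as a number 1 percentage points lower from compound 3 to compound 4 (within the scatter). Compound 4 is thus expected to give about 100% in this assay, within a range of 85% to 115%.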

Compound 4, a percentage reported as activity, at one concentration (the size of the read-out at that concentration, not a potency): 101%
Beside the measured number, compound 4's estimate is 1 percentage points below it; low and high end bracket the measured number.
By their numbers in this assay, from the lowest: compound 2; then compound 1; then compounds 3 and 4 (each within the scatter of the next).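

In this assay, a methyl five bonds along the chain from an aromatic carbon gives no change at the digits printed from compound 3 to compound 4 (within the scatter), so the high number holds through this step, and the large gaps to the shorter chains remain, with a number 70 percentage points higher from compound 2 to compound 4 (beyond the scatter) and a number 54 percentage points higher from compound 1 to compound 4 (beyond the scatter). The same methyl-for-hydrogen change therefore does not read alike at different places on the chain: the same change on two cores in this assay, a number 16 percentage points lower (beyond the scatter) from compound 1 to compound 2 and no change at the digits printed (within the scatter) from compound 3 to compound 4, 16 percentage points apart, beyond the scatter of two such steps. The rise on longer extension also differs with the starting chain: the same change on two cores in this assay, a number 54 percentage points higher (beyond the scatter) from compound 1 to compound 3 and a number 70 percentage points higher (beyond the scatter) from compound 2 to compound 4, 16 percentage points apart, beyond the scatter of two such steps.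

The compounds shown leave open where between the propyl chain of compound 2 and the pentyl chain of compound 3 the number turns upward, a question a butyl chain would bear on. They also leave open whether a heptyl chain, or a chain carrying a hydroxyl, would keep the number where it stands.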